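A few compounds are considered here, and "the series" means these few. Any claim that something is new, unique, unknown or untested is made for them only; others in the source may bear on it.

In a functional assay on K562 cells (Homo sapiens) for antiproliferative activity, read by trypan blue exclusion, with a stated time of 48 h, tested at 10 uM (a higher number here means more inhibition of growth at the concentration tested, a lower number less inhibition of growth), compound 1 `NC(=O)c1cc(Br)ccc1NC(=O)/C=C/c1ccccc1Br` gives 46.2%, compound 2 `NC(=O)c1cc(Br)ccc1NC(=O)/C=C/c1cccc(Br)c1` gives 45.9% and compound 3 `Cc1cccc(/C=C/C(=O)Nc2ccc(Br)cc2C(N)=O)c1` gives 43.8%. Compound 3 therefore stands level with the other two, within the scatter of both. Compound 4 `Cc1ccc(/C=C/C(=O)Nc2ccc(Br)cc2C(N)=O)cc1` has the same atoms as compound 3, joined differently: 4-methylphenyl in place of 3-methylphenyl on a double-bonded chain carbon bound to a double-bonded chain carbon, with 4-methylphenyl in place of 3-methylphenyl on a double-bonded chain carbon bound to a double-bonded chain carbon. The nearest parallel is 3-bromophenyl in place of 2-bromophenyl, a number 0.3 percentage points lower from compound 1 to compound 2 (within the scatter). The other two steps, a number 2.4 percentage points lower from compound 1 to compound 3 (within the scatter) and a number 2.1 percentage points lower from compound 2 to compound 3 (within the scatter), are just as small. None of them tests the 4-methylphenyl group itself. The estimated step is a number 1.2 percentage points higher from compound 3 to compound 4 (within the scatter), nothing beyond the scatter. The expected value for compound 4 is 45%, with a range from 36% to 54%.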

Compound 4, percent growth inhibition at one concentration: 45.9%
Beside the measured number, compound 4's estimate is 0.9 percentage points below it; the measured number falls inside the stated range.
By their numbers in this assay, from the lowest: compounds 3, 2, 4 and 1 (each within the scatter of the next).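

In this assay, 4-methylphenyl in place of 3-methylphenyl on this double-bonded chain carbon gives no step beyond the scatter (a number 2.1 percentage points higher from compound 3 to compound 4 (within the scatter)). The 4-methylphenyl group also stands level with both bromophenyl groups (no change at the digits printed from compound 2 to compound 4 (within the scatter); a number 0.3 percentage points lower from compound 1 to compound 4 (within the scatter)). Among these four compounds, then, neither the kind of group tested nor its place on the phenyl ring separates the numbers. No measurement shown accounts for this evenness. Going by these compounds, whether an amine or a carboxylic acid on that phenyl ring would give a different number stays open.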